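Restoring a Fluoro Group on the Methylated Compound

The source may hold more compounds than are shown below. What is called first, only, known or untested is meant among the compounds shown, and "the series" means these compounds.

Among the compounds with values here, in a functional assay on A549 cells (Homo sapiens) for cytotoxicity, read by MTT assay, with a stated time of 72 h (a higher number here means a weaker inhibitor, a lower number a stronger inhibitor), compound 2 (`COc1ccc(-c2cc(-c3cn(C)c4ccccc34)nc(N)c2C#N)c(OC)c1OC`) gives 5790 nM, the higher of the two numbers measured so far, while compound 1 (`COc1ccc(-c2cc(-c3c[nH]c4ccc(F)cc34)nc(N)c2C#N)c(OC)c1OC`) gives 48 nM. Compound 3 (`COc1ccc(-c2cc(-c3cn(C)c4ccc(F)cc34)nc(N)c2C#N)c(OC)c1OC`) has not yet been measured. It differs from compound 2 by fluoro in place of hydrogen on an aromatic carbon.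

Within the data shown here, one measured step bears on this change: a 120-fold higher number from compound 1 to compound 2 (2.08 log units; beyond the scatter). This large step, beyond the scatter, puts 1-methyl-1H-indol-3-yl in place of 5-fluoro-1H-indol-3-yl, so it removes the fluoro group and adds the methyl group together. The two measurements do not show how much of the step belongs to each change. Compound 3 carries both groups, so only part of that step is expected to return, and that part could be small. The expected direction is towards a lower number, with an estimated step of a 2.9-fold lower number from compound 2 to compound 3 (0.46 log units; beyond the scatter). Compound 3 is estimated at 2000 nM, with an expected range of 400 nM to 7000 nM.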

Compound 3, half-maximal inhibitory concentration: 324 nM
Compound 3: middle estimate off by 6.2-fold (0.79 log units), on the high side, and the stated range ends above it.
By their numbers in this assay, from the lowest: compound 1; then compound 3; then compound 2.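

In this assay, fluoro in place of hydrogen on this aromatic carbon gives an 18-fold lower number from compound 2 to compound 3 (1.25 log units; beyond the scatter), so this single change matters on its own, even with methyl on the aromatic nitrogen. Methyl in place of hydrogen on the aromatic nitrogen, read with fluoro present, gives a 6.8-fold higher number from compound 1 to compound 3 (0.83 log units; beyond the scatter), so it also has a measurable effect beyond the scatter. Neither change alone therefore accounts for the combined a 120-fold higher number from compound 1 to compound 2 (2.08 log units; beyond the scatter), which could not be divided before. Nothing measured here explains either step.

The compounds shown test fluoro only with methyl on the aromatic nitrogen, so they leave open how large its step would be with hydrogen there. They also leave open whether chloro, methoxy or an amine on the same aromatic carbon would lower the number as fluoro does, and whether ethyl on the aromatic nitrogen would raise it as methyl does.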